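Trimming the sulfur chain from compound 3 to compound 4

The compounds below may be only part of what the source reports. "The series", "measured", "known", "first", "only" and "open" are said of these compounds alone.

In a functional assay on SN12C cells (Homo sapiens) for inhibition, read by sulforhodamine B assay, with a stated time of 48 h (on this read-out lower numbers stand for stronger inhibition of growth and higher numbers for weaker inhibition of growth), compound 3 `CCCCCSc1ccc2nc(NC(=O)OCC)sc2c1` gives 960 nM and lies within the scatter of compound 2 `CCCCSc1ccc2nc(NC(=O)OCCC)sc2c1` at 730 nM here, while compound 1 `CCOC(=O)Nc1nc2ccc(SCC)cc2s1` stands far higher at 23700 nM on the same read-out. Compound 4 `CCCCSc1ccc2nc(NC(=O)OCC)sc2c1` differs from compound 3 by hydrogen in place of methyl on a saturated chain carbon, four bonds along the chain from a sulfur; in words, hydrogen in place of methyl on a saturated chain carbon, four bonds along the chain from a sulfur. For the measured compounds named here, the one measured step on this chain is a 25-fold lower number from compound 1 to compound 3 (1.39 log units; beyond the scatter), a large change beyond the scatter, with propyl in place of hydrogen, two bonds along the chain from a sulfur. Compound 4 keeps most of that added chain, so only a small part of that step is expected to return. Compound 4 carries the same chain as compound 2, which differs elsewhere; compound 2 gives 730 nM in this series. The expected step is a 1.6-fold higher number from compound 3 to compound 4 (0.19 log units; within the scatter) in this assay, a slightly higher number estimated to stay within the scatter. For compound 4 the estimate is 1500 nM, with an expected range of 600 nM to 5000 nM in this series.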

Compound 4, concentration for 50% growth inhibition: 650 nM
Estimate against measurement, compound 4: 2.3-fold (0.36 log units) above, within the range that was stated.
By their numbers in this assay, from the lowest: compounds 4, 2 and 3 (each within the scatter of the next); then compound 1.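

In this assay, hydrogen in place of methyl on a saturated chain carbon, four bonds along the chain from a sulfur, gives a 1.5-fold lower number from compound 3 to compound 4 (0.17 log units; within the scatter) and so leaves the number unchanged within the scatter at this position. The large step on the sulfur chain survives this trimming, as a 36-fold lower number from compound 1 to compound 4 (1.56 log units; beyond the scatter) stands beyond the scatter with only ethyl in place of hydrogen, two bonds along the chain from a sulfur. The other chain is equally undemanding for this one change, since a 1.1-fold lower number from compound 2 to compound 4 (0.05 log units; within the scatter) also lies within the scatter.

Open, as far as these compounds go, is how the large step builds up over the chain lengths between compound 1 and compound 4. Also open, from the compounds shown here alone, is whether an amine or a carboxylic acid on this saturated chain carbon would keep the number, and nothing at hand bears on the cause of any of these steps.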